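The source may report more compounds than this note shows. Statements on the series, on what has been measured and on what is new or still open speak of the compounds shown alone.

Compound 1 `CNC(=O)c1cc(C(=O)N[C@H]2CC[C@H](O)CC2)c([C@@H](C)c2cccc(OC)c2)o1`: 868 ug/mL
Compound 2 `CNC(=O)c1cc(C(=O)NC2CC2)cn(Cc2cccc3[nH]ccc23)c1=O`: 17 ug/mL
Compound 3 `CC[C@@H](c1ccccc1)n1nc(C(=O)NC)cc1C(=O)N[C@H]1CC[C@H](O)CC1`: > 1000 ug/mL

Of the compounds shown here, three have so far been measured in a physicochemical assay for solubility, read by HPLC, in simulated intestinal fluid, with a stated time of 16 h, at pH 6.5; a lower number here means a less soluble compound, a higher number a more soluble compound. For compound 3 the result is not a number but a limit of the measurement, > 1000 ug/mL, meaning the compound dissolved at least as far as this assay can report (the limit of > 1000 ug/mL in this assay, at which 1 of the 3 values shown sits). Of the two compounds with actual numbers, compound 1 gives the higher one, 868 ug/mL, while compound 2 gives a much lower value, 17 ug/mL; that gap lies well beyond the usual scatter of repeated measurements. Compound 2 is built on a different core from compound 1, so the two values show a difference between two quite different molecules rather than the effect of one small change.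

Compound 4 `CNC(=O)c1cc(C(=O)N[C@H]2CC[C@H](O)CC2)c([C@@H](C)c2ccccc2)o1` keeps the whole core of compound 1 and changes only one spot: hydrogen in place of methoxy on an aromatic carbon. This is the removal of a small group from the outer phenyl ring, leaving a plain phenyl in place of a 3-methoxyphenyl. For such a small change, the expected step of a 1.0-fold lower number from compound 1 to compound 4 (0.01 log units; within the scatter) is none beyond the scatter. Compound 4 is therefore estimated at 850 ug/mL, within a range of 350 ug/mL to 1000 ug/mL, with a fair chance that this assay again reports only a limit.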

Compound 4, solubility: 827 ug/mL
Compound 4: the middle estimate sits 1.0-fold (0.01 log units) above what was measured; the measured number falls inside the stated range.
By their numbers in this assay, from the lowest: compound 2; then compounds 4 and 1 (each within the scatter of the next). At a limit, above all of these: compound 3.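

Replacing the methoxy group on the aromatic ring with hydrogen gives, in this assay, a 1.0-fold lower number from compound 1 to compound 4 (0.02 log units; within the scatter). This is the first pair shown that differs in only one place, so it gives the first direct reading of this position, which the earlier comparison between different cores could not provide. Here, the loss of two heavy atoms and one hydrogen-bond acceptor, turning 3-methoxyphenyl into phenyl, leaves a difference that cannot be told apart from the ordinary spread of repeated measurements.

This single pair tests only the swap of methoxy for hydrogen, so it leaves open whether an amine, a carboxylic acid or a longer chain such as butoxy on the same aromatic carbon would shift the number beyond the scatter. A group that raised the number could also be followed only a limited way, because the values of this series stand close to the top of what is reported: the limit of > 1000 ug/mL in this assay, at which 1 of the 4 values shown sits.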